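This account rests on a few compounds, and the source may have more. Where it says the series, first, only, none or still open, it means among the compounds named here.

Compound 3 `Cn1cc(NC(=O)c2ccncc2Nc2cc(-c3ccc4ccn(C)c4c3)c3nccnc3c2)cn1` sits second highest among the three numbers in an assay for inhibition of 6-phosphofructo-2-kinase/fructose-2,6-bisphosphatase 3 (Homo sapiens), read by ADP-Glo, with a stated time of 2 h (a lower number here means a stronger inhibitor, a higher number a weaker inhibitor), at 33 nM; compound 2 `CN(Cc1cncnc1)S(=O)(=O)c1ccccc1Nc1cc(-c2ccc3ccn(C)c3c2)c2nccnc2c1` gives 62 nM and compound 1 `CN1CCC(CNS(=O)(=O)c2ccccc2Nc2cc(-c3ccc4ccn(C)c4c3)c3nccnc3c2)C1` gives 11 nM. Compound 4 `CN1CC(NC(=O)c2ccncc2Nc2cc(-c3ccc4ccn(C)c4c3)c3nccnc3c2)C1` differs from compound 3 by 1-methylazetidin-3-yl in place of 1-methyl-1H-pyrazol-4-yl on an amide-type nitrogen. Within the data shown here, the only measured step that bears on it is a 5.6-fold higher number from compound 1 to compound 2 (0.75 log units; beyond the scatter), where an aromatic heterocycle replaced a saturated methylated ring; compound 3 to compound 4 runs the opposite way, though on an amide-type nitrogen rather than a sulfonyl sulfur. A lower number is therefore expected in this assay, estimated as a 2.2-fold lower number from compound 3 to compound 4 (0.34 log units; beyond the scatter). Compound 4 is expected to give about 15 nM, within 5 nM to 45 nM.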

Compound 4, half-maximal inhibitory concentration: 30 nM
The estimate for compound 4 lay 2.0-fold (0.30 log units) below the measured number; the measured number falls inside the stated range.
By their numbers in this assay, from the lowest: compound 1; then compounds 4, 3 and 2 (each within the scatter of the next, the first and the last beyond it).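

In this assay, on the amide-type nitrogen, 1-methylazetidin-3-yl in place of 1-methyl-1H-pyrazol-4-yl gives a 1.1-fold lower number from compound 3 to compound 4 (0.04 log units; within the scatter), so this change does not separate the two groups at this position. Among these compounds, the step of a 5.6-fold higher number from compound 1 to compound 2 (0.75 log units; beyond the scatter), on a sulfonyl sulfur and with different groups, has no counterpart of that size here. Nothing at hand accounts for this result. As far as these compounds go, whether a carboxylic acid or a longer chain ending in a dimethylamine on the same nitrogen would shift the number remains open, as does whether 1-methylpiperidin-4-yl would track 1-methylazetidin-3-yl.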